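The compounds below may be only part of what the source reports. "The series", "measured", "known", "first", "only" and "open" are said of these compounds alone.

Of the compounds shown here, three of a shared core have been measured. Compound 1 `CS/C(=N\C(=O)c1csc([N+](=O)[O-])c1)NC(=O)c1csc([N+](=O)[O-])c1` gives 51800 nM in a functional assay on HT-29 cells (Homo sapiens) for cytotoxicity, read by MTT assay, with a stated time of 72 h; on this read-out lower numbers stand for stronger inhibition of growth and higher numbers for weaker inhibition of growth. Compound 2 `CS/C(=N\C(=O)c1cccs1)NC(=O)c1cccs1`, which lacks the nitro groups, gives 77900 nM in this assay. Compound 3 `O=C(/N=C(/NC(=O)c1csc([N+](=O)[O-])c1)[Se]Cc1ccccc1)c1csc([N+](=O)[O-])c1` gives 9250 nM and stands lowest of the three numbers, beyond the scatter from both compound 1 and compound 2. Compound 4 `C[Se]/C(=N\C(=O)c1csc([N+](=O)[O-])c1)NC(=O)c1csc([N+](=O)[O-])c1` differs from compound 3 by hydrogen in place of phenyl on a saturated chain carbon bound to a selenium atom, so that benzyl becomes methyl at the selenium. For the measured compounds named here, the only measured step that bears on this change is a 5.6-fold lower number from compound 1 to compound 3 (0.75 log units; beyond the scatter), and that step carried two changes at once: sulfur to selenium and methyl to benzyl. Compound 4 undoes the second of these while keeping the selenium. Going by the values given here, no measured pair separates the two parts. As far as these compounds go, how much of that step belongs to the benzyl alone is unknown. He therefore expects a number for compound 4 higher than that of compound 3 but not the whole of the step back to compound 1, an expected 2.7-fold higher number from compound 3 to compound 4 (0.43 log units; beyond the scatter). His estimate for compound 4 is 25000 nM, expected to fall between 9000 nM and 65000 nM.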

Compound 4, concentration for 50% growth inhibition: 0.63 nM
Compound 4: the middle estimate sits 40000-fold (4.60 log units) above what was measured; measured number outside the range, below it.
By their numbers in this assay, from the lowest: compound 4; then compound 3; then compounds 1 and 2 (each within the scatter of the next).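

In this assay, the change from benzyl to methyl at the selenium gives a 15000-fold lower number from compound 3 to compound 4 (4.17 log units; beyond the scatter) and so isolates a part of the change that earlier measurements left joined with the exchange of sulfur for selenium. With the methyl kept, the exchange of sulfur for selenium alone gives an 82000-fold lower number from compound 1 to compound 4 (4.91 log units; beyond the scatter) and shows that, among these compounds, the much smaller a 5.6-fold lower number from compound 1 to compound 3 (0.75 log units; beyond the scatter) combined two changes pulling the number in opposite directions. Nothing available accounts for the size of either step.

As far as these compounds go, whether an ethyl group or a longer chain on the selenium stays near compound 4 or moves toward compound 3 remains open. Also open, from the compounds shown here alone, is whether a selenium exchange would have a similar effect on the core of compound 2, which lacks the nitro groups.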